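The compounds below may be only part of what the source reports. "The series", "measured", "known", "first", "only" and "open" are said of these compounds alone.

Compound 1 `Cc1ccccc1-n1nncc1CN1C(=O)C2(C(C#N)=C(N)Oc3c2c2nc4ccccc4nc2c2ccccc32)c2ccccc21`: in an ADME assay on HUVEC cells (Homo sapiens) for antiproliferative activity, read by MTT assay, with a stated time of 48 h (on this read-out lower numbers stand for stronger inhibition and higher numbers for weaker inhibition), compound 1 gives > 50000 nM, which is a limit of the assay. Compound 2 `N#CC1=C(N)Oc2c(c3nc4ccccc4nc3c3ccccc23)C12C(=O)N(Cc1cnnn1-c1ccc([N+](=O)[O-])cc1)c1ccccc12`: compound 2 gives > 50000 nM, also a limit. Compound 3 `N#CC1=C(N)Oc2c(c3nc4ccccc4nc3c3ccccc23)C12C(=O)N(Cc1cnnn1-c1cccc(S(N)(=O)=O)c1)c1ccccc12`: compound 3 gives 38600 nM.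

Going by the values given here, compound 3 thus holds the only number in the set. The two other values are limits (the limit of > 50000 nM in this assay, at which 2 of the 3 values shown sit). Compound 4 `Cc1ccc(-n2nncc2CN2C(=O)C3(C(C#N)=C(N)Oc4c3c3nc5ccccc5nc3c3ccccc43)c3ccccc32)cc1Cl` is not yet measured; it differs from compound 3 by 3-chloro-4-methylphenyl in place of 3-sulfamoylphenyl on an aromatic nitrogen. Among the compounds with values here, the steps that bear on this run the other way: an at least 1.2-fold lower number from compound 1 to compound 3 (0.11 log units; that floor lies within the scatter) and an at least 1.2-fold lower number from compound 2 to compound 3 (0.11 log units; that floor lies within the scatter), both floors within the scatter. Removing the 3-sulfamoylphenyl brings compound 4 back toward compound 1 and compound 2, which sit at the limit (the limit of > 50000 nM in this assay, at which 2 of the 3 values shown sit). The number is therefore expected to rise, a 1.6-fold higher number from compound 3 to compound 4 (0.19 log units; within the scatter), with a limit the most likely report. Compound 4 is estimated at 60000 nM, range 25000 nM to 150000 nM.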

Compound 4, half-maximal inhibitory concentration: > 50000 nM
Compound 4: a limit, no number (the forecaster's own chance of this, stated with the estimate: 65%); the middle value does not contradict the limit.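

In this assay, 3-chloro-4-methylphenyl in place of 3-sulfamoylphenyl on the aromatic nitrogen gives an at least 1.2-fold higher number from compound 3 to compound 4 (0.11 log units; that floor lies within the scatter), so this floor alone does not separate the two compounds. With a third substituted phenyl, compound 4 also reports only a limit: the limit of > 50000 nM in this assay, at which 3 of the 4 values shown sit. The steps to compound 4 from compound 1 and compound 2 cannot be read, since both ends of each are limits.

Going by these compounds, whether the number of compound 3 depends on the sulfamoyl group remains open. A phenyl carrying a carboxylic acid or an amine in its place would bear on this.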